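A few compounds are considered here, and "the series" means these few. Any claim that something is new, unique, unknown or untested is made for them only; others in the source may bear on it.

Measured in a functional assay on A549 cells (Homo sapiens) for antiproliferative activity, read by MTT assay, with a stated time of 72 h; a lower number here means a stronger inhibitor, a higher number a weaker inhibitor:
- compound 1 `Nc1nc(N)c2cc(CSC(=S)N3CCN(c4ccccc4)CC3)ccc2n1`: 2970 nM
- compound 2 `Cc1ccc(N2CCN(C(=S)SCc3ccc4nc(N)nc(N)c4c3)CC2)cc1`: 2190 nM
- compound 3 `Nc1nc(N)c2cc(CSC(=S)N3CCN(c4ccc(Cl)cc4)CC3)ccc2n1`: 5210 nM

Compound 3 is separated clearly from only one of the other two compounds. The gap is a 2.4-fold higher number from compound 2 to compound 3 (0.38 log units; beyond the scatter), while the other comparison shows a 1.8-fold higher number from compound 1 to compound 3 (0.24 log units; within the scatter).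

The next compound, compound 4 `Nc1nc(N)c2cc(CSC(=S)N3CCN(c4ccccc4[N+](=O)[O-])CC3)ccc2n1`, keeps the shared core and changes only the aromatic group: 2-nitrophenyl in place of 4-chlorophenyl on an amine nitrogen in a ring. In words, this is 2-nitrophenyl in place of 4-chlorophenyl on an amine nitrogen in a ring.

Within the data shown here, three measured steps bear on this change, since each alters a group on an aromatic carbon of this same part of the molecule. Placing methyl on the ring gives a 1.4-fold lower number from compound 1 to compound 2 (0.13 log units; within the scatter), and placing chloro there gives a 1.8-fold higher number from compound 1 to compound 3 (0.24 log units; within the scatter). Exchanging the two gives a 2.4-fold higher number from compound 2 to compound 3 (0.38 log units; beyond the scatter). These steps are small, and only the last passes the scatter, modestly. Among the measured compounds shown here, none of the measured compounds carries a nitro group, so the data offer no direct guide to that group, and the range must stay wide.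

A large shift is therefore not expected, and any change in this assay is expected to stay within the scatter. The expected step is a 1.4-fold lower number from compound 3 to compound 4 (0.16 log units; within the scatter).

For compound 4 the estimated value is 3600 nM, with an expected range from 1500 nM to 8500 nM.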

Compound 4, half-maximal inhibitory concentration: 4360 nM
Compound 4: the middle estimate sits 1.2-fold (0.08 log units) below what was measured; measured number inside the range.
By their numbers in this assay, from the lowest: compounds 2, 1, 4 and 3 (each within the scatter of the next, the first and the last beyond it).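

The new result adds a different kind of group to this part of the molecule. The 2-nitrophenyl group has more heavy atoms than the 4-chlorophenyl group it replaces and brings two hydrogen-bond acceptors, yet in this assay the exchange gives only a small step (a 1.2-fold lower number from compound 3 to compound 4 (0.08 log units; within the scatter)), and the steps from the plain phenyl compound (a 1.5-fold higher number from compound 1 to compound 4 (0.17 log units; within the scatter)) and the 4-methylphenyl compound (a 2.0-fold higher number from compound 2 to compound 4 (0.30 log units; within the scatter)) also stay within the scatter. So among these four compounds, a nitro group on the aromatic ring attached to the amine nitrogen produces no step that can be separated from repeat-measurement noise, even though the gap between compound 2 and compound 3 remains the only one beyond the scatter. No accompanying measurement explains why these steps are so small.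

Going by these compounds, whether a nitro group elsewhere on this aromatic ring would behave the same way remains open. So does whether an amine or a carboxylic acid on the ring, or a cyclohexyl ring in place of the aromatic ring, would move the number beyond the scatter.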